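This account rests on a few compounds, and the source may have more. Where it says the series, first, only, none or still open, it means among the compounds named here.

Compound 1 `CCN(CC)CN1C(=O)/C(=N\c2nc3ccc(C)cc3s2)c2c(Br)cccc21` was measured in a functional assay on MDA-MB-468 cells (Homo sapiens) for cytotoxicity, read by sulforhodamine B assay, with a stated time of 48 h (a lower number here means a stronger inhibitor of growth, a higher number a weaker inhibitor of growth), where compound 1 gives 43100 nM. Two further compounds share a different core: in this assay compound 3 `O=C1C(=O)N(CN(c2ccccc2)c2ccccc2)c2cccc(Br)c21` gives 63300 nM, and in this assay compound 2 `O=C1C(=O)N(CN(c2ccccc2)c2ccccc2)c2cccc(Cl)c21` gives 14400 nM. The difference between the core of compound 1 and the core of compound 3 is not broken down here; the values of compound 1 and compound 3 lie within the scatter of each other. Between compound 3 and compound 2 the change is chloro in place of bromo on an aromatic carbon, and it made a 4.4-fold lower number from compound 3 to compound 2 (0.64 log units; beyond the scatter). Compound 4 `CCN(CC)CN1C(=O)/C(=N\c2nc3ccc(C)cc3s2)c2c(Cl)cccc21` has not yet been measured in this assay. It differs from compound 1 by chloro in place of bromo on an aromatic carbon; the place reads the same in both pairs, so this is the same change, now made on the core of compound 1. Because a 4.4-fold lower number from compound 3 to compound 2 (0.64 log units; beyond the scatter) was observed on another core with a single precedent, the step expected for compound 4 is a 2.7-fold lower number from compound 1 to compound 4 (0.43 log units; beyond the scatter), somewhat smaller and with wide uncertainty. Compound 4 is therefore estimated at 16000 nM, between 6000 nM and 45000 nM in this assay.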

Compound 4, concentration for 50% growth inhibition: 27300 nM
Compound 4: the middle estimate sits 1.7-fold (0.23 log units) below what was measured, within the range that was stated.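

In this assay, chloro in place of bromo on an aromatic carbon gave a 1.6-fold lower number from compound 1 to compound 4 (0.20 log units; within the scatter), so on the core of compound 1 this change separates the two compounds by no more than the usual scatter. The step seen on the other core therefore did not carry over at its full size: the same change on two cores in this assay, a 4.4-fold lower number (0.64 log units; beyond the scatter) from compound 3 to compound 2 and a 1.6-fold lower number (0.20 log units; within the scatter) from compound 1 to compound 4, 2.8-fold (0.44 log units) apart, beyond the scatter of two such steps In this series, a step read on one core is thus a poor guide to its size on the other, but with a single pair on each core this does not show why the two cores differ or how the change would behave on a further core.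

The compounds shown carry only bromo or chloro at this place, which leaves open how fluoro, methoxy or a plain hydrogen there would read on either core. They also leave open whether a cyclic amine such as morpholine or piperidine, in place of the diethylamino group of compound 4, would alter the growth inhibition.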